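The compounds below may be only part of what the source reports. "The series", "measured", "known", "first", "only" and "open" are said of these compounds alone.

Compound 1, `CN1C(=O)/C(=C(/S)N(C)c2ccccc2)C(=O)c2cc(Br)ccc21`, gives 56% in a functional assay on the whole organism for inhibition, with Mus musculus as the target, at a dose of 10 mg/kg by the oral route; on this read-out higher numbers stand for more inhibition at the one dose given (going by the name of the read-out) and lower numbers for less inhibition. Compound 3, `CN1C(=O)/C(=C(/S)N(C)c2ccc(Br)cc2)C(=O)c2cc(Cl)ccc21`, gives 50%. Compound 2, `CN1C(=O)/C(=C(/S)N(C)c2ccc(OC(F)(F)F)cc2)C(=O)c2cc(Cl)ccc21`, gives 39%.

Compound 1 has the highest of the three numbers in this assay, but its gap to compound 3 lies within the scatter, so the two cannot be ordered; only compound 2 stands clearly lower. The step of a number 11 percentage points lower from compound 3 to compound 2 (beyond the scatter) corresponds to the change (trifluoromethoxy in place of bromo on an aromatic carbon), on a ring para to a large group. The cores of compound 1 and compound 3 differ, and that difference is not broken down here.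

Compound 4, `CN1C(=O)/C(=C(/S)N(C)c2ccccc2)C(=O)c2cc(OC(F)(F)F)ccc21`, is not yet measured in this assay. It differs from compound 1 by trifluoromethoxy in place of bromo on an aromatic carbon, on a ring that is part of a fused system of two rings, meta and para to a fused ring. This is the same kind of change as from compound 3 to compound 2, made at a different place. Because the earlier step was a number 11 percentage points lower from compound 3 to compound 2 (beyond the scatter), a step of comparable size, a number 9 percentage points lower from compound 1 to compound 4 (within the scatter), is expected for compound 4. Compound 4 is therefore estimated at 47%, with a likely range from 30% to 62%.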

Compound 4, a percentage reported as inhibition, in the whole organism at one dose (the size of the read-out at that dose, not a potency): 19%
Compound 4: middle estimate off by 28 percentage points, on the high side; the whole stated range lies above it.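

In this assay, trifluoromethoxy in place of bromo on the fused system brings a number 37 percentage points lower from compound 1 to compound 4 (beyond the scatter). The change lowers the number on both cores, but its size does not carry over from one core to the other: the same change on two cores in this assay, a number 11 percentage points lower (beyond the scatter) from compound 3 to compound 2 and a number 37 percentage points lower (beyond the scatter) from compound 1 to compound 4, 26 percentage points apart, beyond the scatter of two such steps The change stands on the fused system of two rings in compound 4 and at a different place in compound 2, so these two pairs cannot tell whether that place, the rest of the core, or both set the steps apart, and they give no rule for any further core.

The compounds shown leave open how other groups would read at the place on the fused system, such as a methoxy group, an amine or a carboxylic acid. They also leave open whether a longer chain in place of the methyl on either nitrogen would alter the size of the step seen with trifluoromethoxy.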